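The source may hold more compounds than are shown below. What is called first, only, known or untested is meant among the compounds shown, and "the series" means these compounds.

Of the compounds shown here, three of the shared core have so far been tested in a functional assay on A-375 cells (Homo sapiens) for antiproliferative activity, read by MTT assay, with a stated time of 24 h, tested at 100 ug/mL; on this read-out higher numbers stand for a stronger effect at the one concentration tested and lower numbers for a weaker effect. Compound 1 `CCc1ccc2nc(C(=O)Nc3c(F)cc(-c4cccc(F)c4)cc3F)c(C)c(O)c2c1` gives 47.3%, compound 2 `Cc1c(C(=O)Nc2c(F)cc(-c3cccc(F)c3)cc2F)nc2ccc(F)cc2c1O` gives 51.3%, and compound 3 `CCOc1ccc2nc(C(=O)Nc3c(F)cc(-c4cccc(F)c4)cc3F)c(C)c(O)c2c1` gives 37.9%. Compound 2 holds the highest of the three numbers, but its margin is set by the step of a number 4 percentage points higher from compound 1 to compound 2 (within the scatter) on one side and by the step of a number 13.4 percentage points lower from compound 2 to compound 3 (beyond the scatter) on the other; the remaining pair shows a number 9.4 percentage points lower from compound 1 to compound 3 (within the scatter).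

Compound 4 `Cc1c(C(=O)Nc2c(F)cc(-c3cccc(F)c3)cc2F)nc2ccc(F)cc2c1C(=O)O` differs from compound 2 by carboxy in place of hydroxy on an aromatic carbon. All three measured steps swap ethyl, fluoro and ethoxy on a different aromatic carbon and leave the hydroxy untouched, so none of them bears directly on this change; the expectation can only rest on the narrow spread of the three known values. The step of a number 6.3 percentage points lower from compound 2 to compound 4 (within the scatter) is therefore expected to stay close to the scatter, with no direction preferred. For compound 4 the estimate in this assay is 45%, with a range from 25% to 62%.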

Compound 4, a percentage reported as inhibition, at one concentration (the size of the read-out at that concentration, not a potency): 64.3%
Beside the measured number, compound 4's estimate is 19.3 percentage points below it; the measured number lies above the stated range.
By their numbers in this assay, from the lowest: compounds 3, 1 and 2 (each within the scatter of the next, the first and the last beyond it); then compound 4.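

Replacing hydroxy with carboxy on the aromatic carbon opposite the ring nitrogen gives a number 13 percentage points higher from compound 2 to compound 4 (beyond the scatter) in this assay. Among these compounds, the earlier steps all varied a different aromatic carbon, so this is the first sign that the read-out also responds to the group at this position, and that this position accepts the larger carboxy group without a loss at the one concentration tested. Nothing shown accounts for the size or direction of this step.

The compounds shown leave open whether a methyl ester, a primary amide or an amine at this carbon would behave like carboxy or like hydroxy. They also leave open whether the step from hydroxy to carboxy would hold with ethyl or ethoxy in place of fluoro on the other aromatic carbon.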